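A few compounds are considered here, and "the series" means these few. Any claim that something is new, unique, unknown or untested is made for them only; others in the source may bear on it.

In a functional assay on cells (Cancer cell lines, Homo sapiens) for cytotoxicity, read by sulforhodamine B assay, with a stated time of 48 h (a lower number here means a stronger inhibitor of growth, a higher number a weaker inhibitor of growth), compound 1 `COc1ccc(OC)c(-c2cc(-c3ccccc3)nn2-c2ccc(S(=O)(=O)NC(C)=O)cc2)c1` gives 3740 nM. Compound 2 `COc1ccc(OC)c(-c2cc(-c3ccc(Cl)cc3)nn2-c2ccc(S(=O)(=O)NC(C)=O)cc2)c1` carries chloro in place of hydrogen on an aromatic carbon and in this assay compound 2 gives 8180 nM, a step of a 2.2-fold higher number from compound 1 to compound 2 (0.34 log units; beyond the scatter). Compound 3 `Oc1ccc(O)c(-c2cc(-c3ccccc3)nn2-c2ccccc2)c1` is built on a different core; the difference between the two cores is not broken down here. In this assay compound 3 gives 28500 nM, the highest of the three numbers. Compound 4 `Oc1ccc(O)c(-c2cc(-c3ccc(Cl)cc3)nn2-c2ccccc2)c1` differs from compound 3 by chloro in place of hydrogen on an aromatic carbon, the same kind of change as that between compound 1 and compound 2, described at a place with the same wording. Among the measured compounds shown here, the only precedent is the step of a 2.2-fold higher number from compound 1 to compound 2 (0.34 log units; beyond the scatter), modest but beyond the scatter. Compound 4 is therefore expected to show a step of a 2.1-fold higher number from compound 3 to compound 4 (0.32 log units; beyond the scatter), resting on that single precedent. Compound 4 is estimated at 60000 nM, with a range from 25000 nM to 150000 nM.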

Compound 4, concentration for 50% growth inhibition: 5750 nM
Beside the measured number, compound 4's estimate is 10-fold (1.02 log units) above it; measured number below the stated range.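

In this assay, the change from phenyl to 4-chlorophenyl gave a 5.0-fold lower number from compound 3 to compound 4 (0.70 log units; beyond the scatter). Set beside the earlier step, the same change did not carry over from one core to the other, and its direction reversed: the same change on two cores in this assay, a 2.2-fold higher number (0.34 log units; beyond the scatter) from compound 1 to compound 2 and a 5.0-fold lower number (0.70 log units; beyond the scatter) from compound 3 to compound 4, 11-fold (1.04 log units) apart, beyond the scatter of two such steps. This shows that, in these two pairs, the step on one core did not predict the step on the other, but it does not show which feature of the cores accounts for the gap or how the change would behave on a further core.

The core of compound 1 and the core of compound 3 differ in more than one place, and the compounds shown do not separate those differences. On these data alone, it also remains open whether another group at the same place, such as bromo or an amine, would follow the chloro step on either core.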